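The compounds below may be only part of what the source reports. "The series", "measured", "known", "first", "only" and "open" are said of these compounds alone.

Compound 2 `COc1ccc(-c2cc(C(=O)/C=C/c3ccc(C)cc3)nc3cc(-c4ccccc4)nn23)cc1OC` is one of two compounds tested in a functional assay on A549 cells (Homo sapiens) for antiproliferative activity, read by MTT assay, with a stated time of 24 h (a lower number here means a stronger inhibitor, a higher number a weaker inhibitor), where compound 2 gives 22200 nM. Compound 1 `COc1ccc(-c2cc(C(=O)/C=C/c3ccccc3)nc3cc(-c4ccccc4)nn23)cc1OC` gives 18600 nM in this assay, and the two numbers lie within the scatter of each other, as the step of a 1.2-fold higher number from compound 1 to compound 2 (0.08 log units; within the scatter) shows. Compound 3 `COc1ccc(-c2cc(/C=C/C(=O)c3ccc(C)c(C)c3)nc3cc(-c4ccccc4)nn23)cc1OC` carries 2-((3,4-dimethylphenyl)carbonyl)ethenyl in place of (2-(4-methylphenyl)ethenyl)carbonyl on an aromatic carbon. Within the data shown here, the only measured step, a methyl added to an aromatic carbon, stayed within the scatter, and no measured step covers the reversed arrangement of the carbonyl and the double bond, so an expected step of a 1.0-fold lower number from compound 2 to compound 3 (0.00 log units; within the scatter) beyond the scatter is not supported. Compound 3 is therefore estimated at 22000 nM, with a range from 8000 nM to 60000 nM.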

Compound 3, half-maximal inhibitory concentration: 9300 nM
Beside the measured number, compound 3's estimate is 2.4-fold (0.37 log units) above it; the measured number falls inside the stated range.
By their numbers in this assay, from the lowest: compounds 3, 1 and 2 (each within the scatter of the next, the first and the last beyond it).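

Among these compounds, replacing (2-(4-methylphenyl)ethenyl)carbonyl with 2-((3,4-dimethylphenyl)carbonyl)ethenyl at this aromatic carbon gives the first change beyond the scatter in this assay (a 2.4-fold lower number from compound 2 to compound 3 (0.38 log units; beyond the scatter)). Measured against the side chain without methyl, the picture is weaker, since a 2.0-fold lower number from compound 1 to compound 3 (0.30 log units; within the scatter) stays within the scatter, so the effect at this position is modest at best. Nothing measured here gives a reason for this result.

Open, from the compounds shown here alone, is whether the swapped order of carbonyl and double bond or the added methyl matters more, since both change together. Also open, going by these compounds, is how an amine or a carboxylic acid on that outer aromatic ring would read.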